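The source may hold more compounds than are shown below. What is called first, only, known or untested is meant among the compounds shown, and "the series" means these compounds.

Compound 1 `CC1CCC(=NNc2ccccc2C(=O)O)c2ncc(C(=O)NO)c(=O)n21`: in a functional assay on the whole organism with Rattus norvegicus as the target (on this read-out higher numbers stand for an effect only at larger amounts of compound and lower numbers for an effect already at smaller amounts), compound 1 gives > 100 umol/kg, which is a limit of the measurement and not a number.
Compound 2 `Cc1cc(C)c(NN=C2CCC(C)n3c2ncc(C(=O)O)c3=O)c(C)c1`: in this assay compound 2 gives 320 umol/kg.
Compound 3 `CC1CCC(=NNc2ccc(Cl)cc2Cl)c2ncc(C(=O)O)c(=O)n21`: in this assay compound 3 gives > 100 umol/kg, again a limit rather than a number.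

Compound 3 therefore stands where the measurement ran out: its result is a limit, and it shares that position with compound 1, as the limit of > 100 umol/kg in this assay, at which 2 of the 3 values shown sit, records. Only compound 2 yields a definite number, and that number is a large one, meaning an effect only at a large amount of compound.

Compound 4 `Cc1cc(NN=C2CCC(C)n3c2ncc(C(=O)O)c3=O)ccc1Br` has not yet been measured in this assay. It differs from compound 3 in a single place: 4-bromo-3-methylphenyl in place of 2,4-dichlorophenyl on an amine nitrogen. The shared core is unchanged. Within the data shown here, no measured pair here differs in only one place, so nothing shows how large a step such a swap of ring substituents produces. Since compound 3 sits at a limit, the step from compound 3 to compound 4 is expected to stay within the scatter, or to show no change at all, and the estimate means the step that the limit leaves unreadable from compound 3 to compound 4. Compound 4 is expected to give about 250 umol/kg, within a range from 80 umol/kg to 1000 umol/kg, and a limit rather than a number is the likelier outcome.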

Compound 4, dose for 50% inhibition: > 100 umol/kg
Compound 4 ended at the assay's limit (the forecaster's own chance of this, stated with the estimate: 60%); the middle value is on the limit's open side.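

Compound 3 and compound 4 both end at a limit rather than at a number, so the step between them cannot be read; they share this position: the limit of > 100 umol/kg in this assay, at which 3 of the 4 values shown sit.

The compounds shown leave open how far past that limit each one lies, and whether 4-bromo-3-methylphenyl in place of 2,4-dichlorophenyl changes the result at all.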